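Fluoro for Bromo, Tried Again on a Second Core

The source may report more compounds than this note shows. Statements on the series, on what has been measured and on what is new or still open speak of the compounds shown alone.

Compound 1 `O=S(=O)(c1ccc(Br)cc1)c1nc2ccccc2nc1N1CCc2ccccc2C1` gives > 50000 nM in a functional assay on HCT-116 cells (Homo sapiens) for cytotoxicity, read by MTT assay, with a stated time of 72 h (a lower number here means a stronger inhibitor, a higher number a weaker inhibitor), and this value is a limit of the assay rather than a number.
Compound 2 `O=S(=O)(c1ccc(F)cc1)c1nc2ccccc2nc1N1CCc2ccccc2C1` gives 16600 nM in this assay.
Compound 3 `O=S(=O)(c1ccc(Br)cc1)c1nc2ccccc2nc1N1CCCC(O)C1` gives 2110 nM in this assay.

Compound 1 and compound 2 share one core and differ in a single place: fluoro in place of bromo on an aromatic carbon. This change produced an at least 3.0-fold lower number from compound 1 to compound 2 (0.47 log units; beyond the scatter). The size of that step is known only as a lower bound, because of the limit of > 50000 nM in this assay, at which 1 of the 3 values shown sits. Compound 3 carries a different core; how its core differs from that of compound 1 is 3-hydroxypiperidin-1-yl in place of 1,2,3,4-tetrahydroisoquinolin-2-yl on an aromatic carbon, and the change gave an at least 23-fold lower number from compound 1 to compound 3 (1.37 log units; beyond the scatter). Of the two numbers measured, compound 3 gives the lower one.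

Compound 4 `O=S(=O)(c1ccc(F)cc1)c1nc2ccccc2nc1N1CCCC(O)C1` has not yet been measured. It stands to compound 3 as compound 2 stands to compound 1: fluoro in place of bromo on an aromatic carbon. The place of the change is described in the same words in both pairs, so this is the same change carried over to the second core. The step from compound 3 to compound 4 in this assay is expected to be a 2.3-fold lower number from compound 3 to compound 4 (0.37 log units; beyond the scatter), resting on the earlier at least 3.0-fold lower number from compound 1 to compound 2 (0.47 log units; beyond the scatter), while allowing that a step seen once on one core need not repeat with the same size on another. Compound 4 is therefore expected to give about 900 nM, most likely between 300 nM and 3000 nM.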

Compound 4, half-maximal inhibitory concentration: 5500 nM
The estimate for compound 4 lay 6.1-fold (0.79 log units) below the measured number; measured number above the stated range.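

On the core of compound 3, fluoro in place of bromo went the other way in this assay, giving a 2.6-fold higher number from compound 3 to compound 4 (0.42 log units; beyond the scatter), whereas the same change lowered the number on the core of compound 1: the same change on two cores in this assay, an at least 3.0-fold lower number (0.47 log units; beyond the scatter) from compound 1 to compound 2 and a 2.6-fold higher number (0.42 log units; beyond the scatter) from compound 3 to compound 4, at least 7.8-fold (0.89 log units) apart, beyond the scatter of two such steps. Among the fluoro compounds, 3-hydroxypiperidin-1-yl in place of 1,2,3,4-tetrahydroisoquinolin-2-yl still lowered the number, giving a 3.0-fold lower number from compound 2 to compound 4 (0.48 log units; beyond the scatter), but this step is smaller than the one seen among the bromo compounds: the same change on two cores in this assay, an at least 23-fold lower number (1.37 log units; beyond the scatter) from compound 1 to compound 3 and a 3.0-fold lower number (0.48 log units; beyond the scatter) from compound 2 to compound 4, at least 7.8-fold (0.89 log units) apart, beyond the scatter of two such steps. So in these four compounds the effect of the fluoro for bromo change did not carry from one core to the other, even in direction, but two pairs cannot show why this happened or predict a third core, and the size of each step that starts from compound 1 is only a bound, as compound 1 stands at a limit of the assay: the limit of > 50000 nM in this assay, at which 1 of the 4 values shown sits.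

The compounds shown leave open whether the flip in direction follows the hydroxy group or the piperidine ring itself, a question that a plain piperidin-1-yl or a morpholin-4-yl group on the same carbon could help to settle. Also open, as far as these compounds go, is how chloro or methoxy in the place of bromo would behave on each of the two cores.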